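Adding Fluoro to a Fast-Cleared Compound

The compounds below may be only part of what the source reports. "The series", "measured", "known", "first", "only" and "open" are said of these compounds alone.

Measured in an ADME assay on microsomes from liver (Homo sapiens) for metabolic stability; on this read-out higher numbers stand for fast clearance and lower numbers for slow clearance:
- compound 1 `COc1ccc2nnn(CC(=O)N[C@@H](C)c3ccc(C)cc3)c(=O)c2c1`: 58 mL/min/kg
- compound 2 `Cc1ccc([C@H](C)NC(=O)Cn2nnc3ccc(C)cc3c2=O)cc1`: 179 mL/min/kg

Of these two, compound 2 has the higher number, at 179 mL/min/kg, which points to the faster clearance. Compound 3 `Cc1ccc([C@H](C)NC(=O)Cn2nnc3c(F)cc(C)cc3c2=O)cc1` differs from compound 2 in a single place: fluoro in place of hydrogen on an aromatic carbon. In plain terms, this is fluoro in place of hydrogen on an aromatic carbon.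

Within the data shown here, only one measured step is available, a 3.1-fold higher number from compound 1 to compound 2 (0.49 log units; beyond the scatter). That step was methyl in place of methoxy, a different swap, so it offers only a loose guide. Among the measured compounds shown here, it does show that one change on an aromatic carbon can move the number in this assay beyond the scatter, but no measured compound tests fluoro. No clear direction can be drawn, so no shift beyond the scatter is expected.

The estimated step is a 1.1-fold lower number from compound 2 to compound 3 (0.05 log units; within the scatter). Compound 3 is expected at 160 mL/min/kg, with an estimated range of 90 mL/min/kg to 280 mL/min/kg.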

Compound 3, clearance: 85 mL/min/kg
Beside the measured number, compound 3's estimate is 1.9-fold (0.27 log units) above it; the measured number lies below the stated range.
By their numbers in this assay, from the lowest: compounds 1 and 3 (each within the scatter of the next); then compound 2.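

In this assay, fluoro in place of hydrogen gives a 2.1-fold lower number from compound 2 to compound 3 (0.32 log units; beyond the scatter), so a change of one atom on this aromatic carbon, ortho to a fused ring and meta to a methyl group, can move the number beyond the scatter. The earlier step showed only what a swap on the carbon bearing the methyl group can do, whereas this one shows that a second carbon of the shared core also matters, with the number moving towards slower clearance. No measurement here explains why the number fell.

From the compounds shown here alone, it remains open whether another group on this carbon, such as chloro, a nitrile or an amine, would move the number further or in the opposite direction. Also open, going by these compounds, is whether fluoro here would give a similar step with methoxy in place of methyl, as in compound 1.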